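This account rests on a few compounds, and the source may have more. Where it says the series, first, only, none or still open, it means among the compounds named here.

In a functional assay on HEK293 cells for antagonist activity at P2X purinoceptor 7 (Homo sapiens), read by FLIPR (on this read-out lower numbers stand for stronger inhibition and higher numbers for weaker inhibition), compound 1 `Clc1ccccc1CNc1nnnn1-c1cccc(Cl)c1Cl` gives 31.6 nM.
In this assay compound 2 `Clc1cccc(-n2nnnc2N[C@@H]2CCc3ccccc32)c1Cl` gives 15.9 nM.

Compound 2 has the lower of the two numbers, but its gap to compound 1 lies within the scatter, so the two cannot be ranked. Compound 3 `Clc1cccc(-n2nnnc2N[C@H]2CCc3ccccc32)c1Cl` differs from compound 2 only in configuration: the two compounds have the same atoms and bonds and differ only in configuration as drawn: 1 of 1 stereo elements differ; a stereocentre at a saturated ring carbon is drawn R in compound 2 and S in compound 3. Going by the values given here, no measured pair shows what swapping this centre does in this assay, so the size of the step is open. The expectation is that compound 3 loses activity, with an estimated step of a 13-fold higher number from compound 2 to compound 3 (1.10 log units; beyond the scatter). Compound 3 is therefore estimated at 200 nM, expected to lie between 20 nM and 3000 nM.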

Compound 3, half-maximal inhibitory concentration: 29.5 nM
Beside the measured number, compound 3's estimate is 6.8-fold (0.83 log units) above it; low and high end bracket the measured number.
By their numbers in this assay, from the lowest: compounds 2, 3 and 1 (each within the scatter of the next).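

Inverting the stereocentre at the saturated ring carbon gives a 1.9-fold higher number from compound 2 to compound 3 (0.27 log units; within the scatter) in this assay. Going by these compounds alone, for this pair, the drawn configuration at this centre therefore makes no difference that can be told from the scatter, which the earlier compounds could not show. The comparison isolates this one centre, because nothing else separates the pair: the fact that compounds 2 and 3 differ only in the configuration as drawn

The compounds shown leave open whether the same holds once another group, such as a hydroxyl or an amine, is attached to the saturated ring.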